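This account rests on a few compounds, and the source may have more. Where it says the series, first, only, none or still open, it means among the compounds named here.

Compound 1 `CCCCCCCCCCCCNC(=O)c1c[nH]c(-c2ccccc2)n1` gives, in a functional assay on A-375 cells (Homo sapiens) for antiproliferative activity, read by sulforhodamine B assay, with a stated time of 48 h (a lower number here means a stronger inhibitor, a higher number a weaker inhibitor), only a limit, > 30000 nM, which is the limit of > 30000 nM in this assay, at which 1 of the 3 values shown sits. Compound 2 `CCCCCCCCCCCCCCNC(=O)c1c[nH]c(-c2ccccc2)n1` gives 18700 nM in this assay. The change between them is ethyl in place of hydrogen on a saturated chain carbon, ten or more bonds along the chain from an amide-type nitrogen, and the step is an at least 1.6-fold lower number from compound 1 to compound 2 (0.20 log units; that floor lies within the scatter). Within the data shown here, compound 3 `CCCCCCCCCCCCCCNC(=O)[C@@H]1CNC(c2ccccc2)=N1` gives 7100 nM in this assay, the lowest of the numbers so far; the difference between its core and the core of compound 1 is not broken down here. Compound 4 `CCCCCCCCCCCCCCCCNC(=O)[C@@H]1CNC(c2ccccc2)=N1` is not yet measured; it differs from compound 3 by ethyl in place of hydrogen on a saturated chain carbon, ten or more bonds along the chain from an amide-type nitrogen, the same change as between compound 1 and compound 2, at the same place. Among the measured compounds shown here, compound 4 is expected to show a step of a 2.0-fold lower number from compound 3 to compound 4 (0.31 log units; beyond the scatter), of about the size of the earlier one, because an at least 1.6-fold lower number from compound 1 to compound 2 (0.20 log units; that floor lies within the scatter) is the only precedent for this change. Compound 4 is therefore estimated at 3500 nM, expected to fall between 1500 nM and 9000 nM.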

Compound 4, half-maximal inhibitory concentration: 10500 nM
Compound 4: middle estimate off by 3.0-fold (0.48 log units), on the low side, outside the stated range (above it).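

In this assay, among these compounds, ethyl in place of hydrogen on a saturated chain carbon, ten or more bonds along the chain from an amide-type nitrogen, gives a 1.5-fold higher number from compound 3 to compound 4 (0.17 log units; within the scatter), so on this core the change produces no step that stands clear of the scatter. Set beside the earlier step, the two results cannot be called alike or different: the same change on two cores in this assay, an at least 1.6-fold lower number (0.20 log units; that floor lies within the scatter) from compound 1 to compound 2 and a 1.5-fold higher number (0.17 log units; within the scatter) from compound 3 to compound 4; the limit leaves it open whether they differ

The pair therefore does not show that the change carries from one core to the other, and it does not show that it fails to carry.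

Still open, going by these compounds, is whether a longer chain than that of compound 4 would give a step beyond the scatter on this core. Also open, on these data alone, is what an amine or a carboxylic acid on that chain would give.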